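A few compounds are considered here, and "the series" means these few. Any claim that something is new, unique, unknown or untested is made for them only; others in the source may bear on it.

Compound 2 `CCN(CC)S(=O)(=O)c1ccc(S(=O)(=O)N2CCC[C@@H](C(=O)NC3CCOCC3)C2)cc1` sits at the weak end of the three compounds measured in a functional assay on MIA PaCa-2 cells (Homo sapiens) for inhibition, read by MTT assay, with a stated time of 3 days; on this read-out lower numbers stand for stronger inhibition and higher numbers for weaker inhibition: compound 2 gives 1350 nM, the highest of the three numbers. Compound 1 `CCN(CC)S(=O)(=O)c1ccc(S(=O)(=O)N2CCC[C@@H](C(=O)N3CCC(OC)CC3)C2)cc1` gives 50 nM, and compound 3 `CN(C)S(=O)(=O)c1ccc(S(=O)(=O)N2CCC[C@@H](C(=O)N3CCC(F)(F)CC3)C2)cc1` gives 72.4 nM. The only single-point step recorded among these is a 27-fold higher number from compound 1 to compound 2 (1.43 log units; beyond the scatter), a large move that exchanges a ring-closed amide for an open amide bearing the oxan-4-yl group.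

Compound 4 `CCN(CC)S(=O)(=O)c1ccc(S(=O)(=O)N2CCC[C@@H](C(=O)N[C@@H]3CCOC3)C2)cc1` differs from compound 2 in one place: oxolan-3-yl in place of oxan-4-yl on an amide-type nitrogen. The amide hydrogen is kept, and the ring attached to the amide nitrogen shrinks by one carbon.

Within the data shown here, no measured step here models a change of this kind. The step from compound 1 to compound 2 concerns the loss of the ring-closed amide, which compound 4 does not reverse, so it speaks only to where compound 2 starts, not to where compound 4 should land. Compound 3 shares neither the open amide nor the same sulfonamide substituent, so its value gives no guidance on this ring swap. The expected step of a 1.1-fold higher number from compound 2 to compound 4 (0.05 log units; within the scatter) in this assay is therefore small, most likely within the usual scatter, with no direction favoured. Compound 4 is estimated at 1500 nM in this assay, between 450 nM and 5000 nM.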

Compound 4, half-maximal inhibitory concentration: 100 nM
For compound 4 the middle estimate is 15-fold (1.18 log units) above the measured one; measured number outside the range, below it.
By their numbers in this assay, from the lowest: compounds 1, 3 and 4 (each within the scatter of the next); then compound 2.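

In this assay the change on the amide-type nitrogen is far from neutral, with a 14-fold lower number from compound 2 to compound 4 (1.13 log units; beyond the scatter) when oxolan-3-yl replaces oxan-4-yl and the amide hydrogen stays in place. The earlier step from compound 1 to compound 2 could be read as a penalty for the open amide itself, but the step of a 2.0-fold higher number from compound 1 to compound 4 (0.30 log units; within the scatter) shows that an amide keeping its hydrogen can stand within the scatter of compound 1, so in these compounds the high number of compound 2 goes with the oxan-4-yl group and not with the open amide as such. Nothing at hand accounts for this difference between the two rings.

The compounds shown leave open whether the defined stereocentre of the oxolan-3-yl group matters, as the mirror-image form of that ring does not appear among them. They also leave open whether the ring oxygen is needed at all, which a cyclopentyl group on the same nitrogen would test, and whether an oxetan-3-yl group or an open 2-methoxyethyl chain would follow compound 4 or compound 2.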